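The compounds below may be only part of what the source reports. "The series", "measured", "known", "first", "only" and "open" are said of these compounds alone.

Of the compounds shown here, two have so far been measured in a functional assay on HFL1 cells (Homo sapiens) for inhibition, read by sulforhodamine B assay, with a stated time of 48 h; on this read-out higher numbers stand for larger maximal responses and lower numbers for smaller maximal responses. Compound 1 `COc1ccc(-c2nnc(NC3=NC(=O)/C(=C/c4ccc(N(C)C)cc4)S3)o2)cc1` gives 52.4% in this assay, and compound 2 `O=C1N=C(Nc2ccc(O)cc2)S/C1=C\c1ccc(Cl)cc1` gives 46.1%. On the bare numbers compound 2 sits below compound 1, but the gap between them lies within the scatter of repeated measurements, so the two cannot really be told apart.

The next compound, compound 3 `O=C1N=C(Nc2ccc(O)cc2)S/C1=C\c1ccccc1`, differs from compound 2 in a single place: hydrogen in place of chloro on an aromatic carbon. Within the data shown here, no step between two measured compounds is available to show how large such a change tends to be, so the expectation rests on the structural change alone. In this assay the change is expected to produce only a small downward step, a number 4.1 percentage points lower from compound 2 to compound 3 (within the scatter), which would not go beyond the scatter. Compound 3 is therefore estimated at 42%, with a range from 28% to 56%.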

Compound 3, largest response reached (Emax), in percent of the reference or control that the assay uses: 23.8%
The estimate for compound 3 lay 18.2 percentage points above the measured number; the whole stated range lies above it.
By their numbers in this assay, from the lowest: compound 3; then compounds 2 and 1 (each within the scatter of the next).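

Going from 4-chlorophenyl to phenyl gives a number 22.3 percentage points lower from compound 2 to compound 3 (beyond the scatter) in this assay, so the group at this place on the aromatic ring, para to a large group, clearly matters for the maximal response. Among these compounds, this single-atom swap was the first change at this position with a measured result, and it shows that even the loss of one chlorine can move the number by more than repeat measurements would. Nothing available here accounts for the size of this step.

With only chloro and hydrogen compared, there is no telling whether other groups at this place, such as fluoro, methoxy, an amine or a carboxylic acid, would give numbers nearer compound 2 or compound 3. From the compounds shown here alone, it also remains open whether the same swap would have a similar effect on the core of compound 1.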